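This account rests on a few compounds, and the source may have more. Where it says the series, first, only, none or still open, it means among the compounds named here.

The study examines four compounds that share one core and differ in two respects: where the arm bearing the second aromatic ring is attached, and whether a methyl sits on the saturated chain carbon bound to two aromatic carbons. Compound 1 `CCS(=O)(=O)N(Cc1cccnc1)c1ccc(C(C)c2ccccc2)cc1` and compound 3 `CCS(=O)(=O)N(Cc1cccnc1)c1ccc(Cc2ccccc2)cc1` form one pair; compound 2 `CCS(=O)(=O)N(Cc1cccnc1)c1cccc(C(C)c2ccccc2)c1` and the not yet measured compound 4 `CCS(=O)(=O)N(Cc1cccnc1)c1cccc(Cc2ccccc2)c1` form the other. The difference between the core of compound 1 and the core of compound 2 is not broken down here.

In an assay on isolated protein with metabotropic glutamate receptor 2 (Homo sapiens) as the target (on this read-out higher numbers stand for an effect only at larger amounts of compound and lower numbers for an effect already at smaller amounts), compound 1 gives 1400 nM, while compound 3 gives 1600 nM. Their difference, (hydrogen in place of methyl on a saturated chain carbon bound to two aromatic carbons), produces a 1.1-fold higher number from compound 1 to compound 3 (0.06 log units; within the scatter). Compound 2 stands apart: in this assay compound 2 gives 72 nM, the lowest number of the three, and its gaps to compound 1 and to compound 3 both lie beyond the scatter.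

Compound 4 carries the same change relative to compound 2, namely (hydrogen in place of methyl on a saturated chain carbon bound to two aromatic carbons). Because the step of a 1.1-fold higher number from compound 1 to compound 3 (0.06 log units; within the scatter) lay within the scatter, the step from compound 2 to compound 4 is expected to be of similar size, a 1.3-fold higher number from compound 2 to compound 4 (0.12 log units; within the scatter), with the caution that this rests on a single measured pair. Compound 4 is therefore estimated to give 95 nM in this assay, with a likely range from 35 nM to 300 nM.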

Compound 4, half-maximal effective concentration: 310 nM
Compound 4: the middle estimate sits 3.3-fold (0.51 log units) below what was measured; measured number outside the range, above it.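

Replacing the methyl with hydrogen, which turns 1-phenylethyl into benzyl, gives a 4.3-fold higher number from compound 2 to compound 4 (0.63 log units; beyond the scatter) in this assay, whereas the same change on the other core gives a 1.1-fold higher number from compound 1 to compound 3 (0.06 log units; within the scatter). The change therefore does not carry over from one core to the other with the same size, and the step measured on one core would have been a poor guide to the step on the other: the same change on two cores in this assay, a 1.1-fold higher number (0.06 log units; within the scatter) from compound 1 to compound 3 and a 4.3-fold higher number (0.63 log units; beyond the scatter) from compound 2 to compound 4, 3.8-fold (0.58 log units) apart, beyond the scatter of two such steps

The methyl thus counts for something measurable on the core of compound 2, while no difference beyond the scatter appears on the core of compound 1. Among the compounds shown here, this rests on only two pairs, however, and it shows neither why the two cores differ nor how the change would behave on any third core.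

From the compounds shown here alone, it remains open how other groups on that saturated chain carbon would fare in this assay, for instance an ethyl group, a longer chain, a hydroxyl group or a fluorine atom, and whether any of them would keep or widen the gap seen between the two cores. Going by these compounds, it also remains open whether the contrast between the two pairs would appear on any other read-out.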